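From Methoxy to Fluoro in Compound 2

The compounds below may be only part of what the source reports. "The series", "measured", "known", "first", "only" and "open" are said of these compounds alone.

Three compounds with a shared core have numbers in a functional assay on A549 cells (Homo sapiens) for antiproliferative activity, read by sulforhodamine B assay, with a stated time of 48 h (a lower number here means a stronger inhibitor of growth, a higher number a weaker inhibitor of growth), so far. Compound 1 (`COc1ccc(Nc2nc(NC3CCCC3)c3ccccc3n2)cc1`) gives 10100 nM with cyclopentyl on a nitrogen, and compound 3 (`CNc1nc(Nc2ccc(OC)cc2)nc2ccccc12`) gives 16100 nM with methyl there. Compound 2 (`CCCNc1nc(Nc2ccc(OC)cc2)nc2ccccc12`) gives 3530 nM with propyl, the lowest number of the three and clear of both others beyond the scatter. Compound 4 (`CCCNc1nc(Nc2ccc(F)cc2)nc2ccccc12`) keeps the propyl and differs from compound 2 by fluoro in place of methoxy on an aromatic carbon and nothing else. For the measured compounds named here, no measured step touches that aromatic carbon. The steps available all change the nitrogen group: a 2.9-fold lower number from compound 1 to compound 2 (0.46 log units; beyond the scatter) and a 4.6-fold higher number from compound 2 to compound 3 (0.66 log units; beyond the scatter) were modest, while a 1.6-fold higher number from compound 1 to compound 3 (0.20 log units; within the scatter) stayed within the scatter. Going by the values given here, they give no direction for this change and suggest only that single changes here have moved the number modestly. The expected step is a 1.3-fold higher number from compound 2 to compound 4 (0.11 log units; within the scatter) and so nothing beyond the scatter is anticipated. For this assay the estimate for compound 4 is 4500 nM with a range from 1600 nM to 12000 nM expected.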

Compound 4, concentration for 50% growth inhibition: 4300 nM
For compound 4 the middle estimate is 1.0-fold (0.02 log units) above the measured one; the range from low to high includes it.
By their numbers in this assay, from the lowest: compounds 2 and 4 (each within the scatter of the next); then compounds 1 and 3 (each within the scatter of the next).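

In this assay, fluoro in place of methoxy on this aromatic carbon, para to a large group, gives a 1.2-fold higher number from compound 2 to compound 4 (0.09 log units; within the scatter) and is the first step shown at this position. The number therefore stays within the scatter when one heavy atom replaces two and the single hydrogen-bond acceptor of the methoxy is lost, whereas two of the three earlier steps, all on the nitrogen group, went beyond the scatter. No evidence is available to explain this result.

With only methoxy and fluoro shown at this carbon, it remains open whether an amine, a carboxylic acid or a longer chain such as butoxy would leave the number as little changed. On these data alone, it is also open whether fluoro would give a similar step with cyclopentyl or methyl on the nitrogen in place of propyl.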